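The source may report more compounds than this note shows. Statements on the series, on what has been measured and on what is new or still open speak of the compounds shown alone.

Measured in an ADME assay on the whole organism (Mus musculus, strain CD1) for metabolic stability, read by LC-MS, with a stated time of 24 h, at a dose of 1 mg/kg by the intravenous route; on this read-out higher numbers stand for a longer-lived compound and lower numbers for a shorter-lived compound:
compound 1 `O=C(O)Cn1nc(Cc2nc3cc(Cl)c(OCC(F)F)cc3[nH]2)c2ccccc2c1=O`: 0.3 h
compound 2 `O=C(O)Cn1nc(Cc2cn3cc(OCC4CC4)c(Cl)cc3n2)c2ccccc2c1=O`: 0.7 h
compound 3 `C[C@H](C(=O)O)c1nn(Cc2cn3cc(OCC4CC4)c(Cl)cc3n2)c2ccccc2c1=O`: 0.8 h

Compound 1 stands lowest of the three numbers; compound 2 is the nearest to it, and both compound 2 and compound 3 lie beyond the scatter from compound 1. Compound 4 `O=C(O)Cn1nc(Cc2nc3cc(Cl)c(OCC4CC4)cc3[nH]2)c2ccccc2c1=O` is not yet measured. It differs from compound 1 in one place: cyclopropyl in place of difluoromethyl on a saturated chain carbon bound to an oxygen on an aromatic ring. Among the compounds with values here, no measured pair covers this change on the core of compound 1; compound 2 and compound 3 carry cyclopropylmethoxy on a core different from that of compound 1, so they are not a direct step. In this assay the step of a 1.7-fold higher number from compound 1 to compound 4 (0.22 log units; within the scatter) is expected to be small and upward, near the edge of the scatter. Compound 4 is expected to give 0.5 h, with a range of 0.2 h to 1.2 h.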

Compound 4, half-life: 0.6 h
Beside the measured number, compound 4's estimate is 1.2-fold (0.08 log units) below it; the measured number falls inside the stated range.
By their numbers in this assay, from the lowest: compounds 1, 4, 2 and 3 (each within the scatter of the next, the first and the last beyond it).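

Working from the shared core in this assay, 2,2-difluoroethoxy to cyclopropylmethoxy gives a 2.0-fold higher number from compound 1 to compound 4 (0.30 log units; within the scatter), so this exchange at this position has no effect that can be separated from the scatter. Within the data shown here, this is the first direct reading of cyclopropyl in place of difluoromethyl, as the earlier cyclopropylmethoxy compounds stood on a different core. No supporting data bear on what sets the half-life of either compound. Still open, from the compounds shown here alone, is whether an amine or a longer chain in place of cyclopropyl would move the half-life beyond the scatter.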